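Adding chloro to the pyridin-2-yl group of compound 3

A few compounds are considered here, and "the series" means these few. Any claim that something is new, unique, unknown or untested is made for them only; others in the source may bear on it.

Measured in a functional assay on Jurkat cells (Homo sapiens) for inhibition, read by CCK-8 assay, with a stated time of 48 h; a higher number here means a weaker inhibitor of growth, a lower number a stronger inhibitor of growth:
compound 1 `Cc1ccccc1Nc1nc(NC2CC2)ncc1Cl`: > 100000 nM (a limit, not a number)
compound 2 `Cc1ccccc1Nc1nc(Nc2ccccc2)ncc1Cl`: > 100000 nM (a limit, not a number)
compound 3 `Cc1ccccc1Nc1nc(Nc2ccccn2)ncc1Cl`: 20100 nM

Compound 3 alone has a true number, 20100 nM. The other two compounds stand at the limit of > 100000 nM in this assay, at which 2 of the 3 values shown sit.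

Compound 4 `Cc1ccccc1Nc1nc(Nc2cc(Cl)ccn2)ncc1Cl` makes one change to compound 3: chloro in place of hydrogen on an aromatic carbon. This turns pyridin-2-yl into 4-chloropyridin-2-yl, with the chloro opposite the ring nitrogen.

The nearest measured steps are an at least 4.9-fold lower number from compound 1 to compound 3 (0.69 log units; beyond the scatter) and an at least 4.9-fold lower number from compound 2 to compound 3 (0.69 log units; beyond the scatter). Both point to lower numbers, but neither tests a chloro group, so only a small drop is expected, probably not clearly beyond the scatter. The estimated change is a 1.7-fold lower number from compound 3 to compound 4 (0.22 log units; within the scatter). For compound 4 the expected value is 12000 nM, within an estimated range of 3000 nM to 50000 nM.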

Compound 4, concentration for 50% growth inhibition: 39600 nM
Beside the measured number, compound 4's estimate is 3.3-fold (0.52 log units) below it, within the range that was stated.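

In this assay, chloro on the aromatic carbon opposite the ring nitrogen gives a 2.0-fold higher number from compound 3 to compound 4 (0.29 log units; within the scatter), so this single chlorine does not clearly separate the two compounds. The 4-chloropyridin-2-yl group still stands apart from phenyl and cyclopropyl, with an at least 2.5-fold lower number from compound 2 to compound 4 (0.40 log units; beyond the scatter) and an at least 2.5-fold lower number from compound 1 to compound 4 (0.40 log units; beyond the scatter). Those two steps start from values that are limits, not numbers: the limit of > 100000 nM in this assay, at which 2 of the 4 values shown sit.

From the compounds shown here alone, whether an amine or a methoxy group on this same carbon would move the number beyond the scatter stays open. So does the effect of chloro on the other carbons of the pyridin-2-yl ring.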